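From 1,3-thiazol-2-yl to furan-3-yl on a shared core

The compounds below may be only part of what the source reports. "The series", "measured", "known", "first", "only" and "open" are said of these compounds alone.

Compound 1 `O=C(Nc1cccc(-c2ccccn2)c1)C(Cl)Cl`: > 50000 nM (a limit)
Compound 2 `O=C(Nc1cccc(-c2nccs2)c1)C(Cl)Cl`: > 50000 nM (a limit)
Compound 3 `O=C(Nc1cccc(-c2ccoc2)c1)C(Cl)Cl`: not yet measured

In a functional assay on NCI-H460 cells (Homo sapiens) for cytotoxicity, read by MTT assay, with a stated time of 68 h (a higher number here means a weaker inhibitor, a lower number a stronger inhibitor), compound 2 stands at > 50000 nM, which is a limit and not a number. Compound 1 also gives only a limit, > 50000 nM. The whole record so far is the limit of > 50000 nM in this assay, at which 2 of the 2 values shown sit.

Compound 3 differs from compound 2 by one exchange on the shared core: furan-3-yl in place of 1,3-thiazol-2-yl on an aromatic carbon.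

For the measured compounds named here, the one measured step that bears on this exchange is a step that the two limits leave unreadable from compound 1 to compound 2. It offers no size to carry over, so no readable change is expected in this assay, and no direction can be given. Compound 3 is therefore expected to remain close to the limit, most likely without giving a number. The expected change is a number no higher from compound 2 to compound 3 (the limit leaves the size open). For compound 3 the estimate is 50000 nM, with an expected range from 20000 nM to 100000 nM.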

Compound 3, half-maximal inhibitory concentration: 37600 nM
Compound 3: middle estimate off by 1.3-fold (0.12 log units), on the high side, within the range that was stated.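

In this assay, for the compounds shown here, compound 3 is the only one of the three to give a number and not a limit, so furan-3-yl on this aromatic carbon gives the first readable value on the shared core. The exchange appears as an at least 1.3-fold lower number from compound 2 to compound 3 (0.12 log units; that floor lies within the scatter), and the exchange from pyridin-2-yl appears as an at least 1.3-fold lower number from compound 1 to compound 3 (0.12 log units; that floor lies within the scatter); both are floors, which leaves the real size of each step open. The step between compound 1 and compound 2 still cannot be read, and limits remain the larger part of the record: the limit of > 50000 nM in this assay, at which 2 of the 3 values shown sit.

As far as these compounds go, it remains open whether the number depends on the furan ring itself, or whether a plain phenyl ring or a thiophen-3-yl group at this position would give a similar value. From the compounds shown here alone, how an amine or a carboxylic acid on this ring would read in this assay also remains open.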